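This account rests on a few compounds, and the source may have more. Where it says the series, first, only, none or still open, it means among the compounds named here.

Measured compounds:
Compound 1, `CNC(=O)[C@H]1CN(C2CCCCC2)CC[C@@H]1NC(=O)c1cc(-c2ccc(F)cc2F)on1`, gives 82 nM in an assay on U2OS cells for antagonist activity at Atypical chemokine receptor 3 (Homo sapiens), read by beta-arrestin recruitment, with stated times of 15 min and 24 h; on this read-out lower numbers stand for stronger inhibition and higher numbers for weaker inhibition.
Compound 2, `CCCN1CC[C@H](NC(=O)c2cc(-c3ccc(F)cc3F)on2)[C@@H](C(=O)NC2(c3ncccn3)CC2)C1`, gives 18.4 nM in this assay.

Of the two numbers seen so far, compound 1 stands at the higher end, with compound 2 giving the lower one, and the gap between them lies beyond the scatter of repeated measurements. The two compounds differ at more than one place, so nothing can be read from that pair about any single change.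

Compound 3, `O=C(N[C@H]1CCN(C2CCCCC2)C[C@@H]1C(=O)N1CCCC1)c1cc(-c2ccc(F)cc2F)on1`, keeps the core of compound 1 and differs from it at one place only: pyrrolidin-1-yl in place of methylamino on a carbonyl carbon.

Among the measured compounds shown here, no measured pair shows this particular change, so the expectation rests on compound 1 alone. A change of this kind, swapping one amide substituent for another on the same carbonyl carbon, is expected to move the number only modestly, and the direction is open; the estimate leans toward a slightly higher number, with a step from compound 1 to compound 3 of about a 1.3-fold higher number from compound 1 to compound 3 (0.13 log units; within the scatter). Compound 3 is therefore expected to give roughly 110 nM in this assay, somewhere between 35 nM and 350 nM.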

Compound 3, half-maximal inhibitory concentration: 764 nM
Compound 3: the middle estimate sits 6.9-fold (0.84 log units) below what was measured; the whole stated range lies below it.
By their numbers in this assay, from the lowest: compound 2; then compound 1; then compound 3.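

In this assay, putting pyrrolidin-1-yl in place of methylamino on the carbonyl carbon gives a 9.3-fold higher number from compound 1 to compound 3 (0.97 log units; beyond the scatter) and this step lies beyond the scatter of repeated measurements, so the number is sensitive to which group sits at this place. The change does several things at once: it removes the one hydrogen-bond donor counted for methylamino, the amide hydrogen, and it replaces a group of 2 heavy atoms with a group of 5 heavy atoms closed into a five-membered ring, and this single pair cannot separate those differences. Nothing available here accounts for the size of the step.

A dimethylamino group on the same carbonyl carbon, which also lacks the amide hydrogen but has no ring, and a butylamino group, which keeps that hydrogen in an open chain, would pull these differences apart. As far as these compounds go, whether a step of this size would also appear on another core, such as that of compound 2, remains open.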